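Swapping acetyl for tert-butyl on an antiproliferative compound

The source may report more compounds than this note shows. Statements on the series, on what has been measured and on what is new or still open speak of the compounds shown alone.

Compound 1 `CCC(=O)c1ccc(OCCCN2CCN(c3ncccn3)CC2)cc1`: 36.9 nM
Compound 2 `CC(=O)c1ccc(OCCCCN2CCN(c3cccnc3)CC2)cc1`: 24.2 nM
Compound 3 `CC(=O)c1ccc(OCCCCN2CCN(c3ccccn3)CC2)cc1`: 24.1 nM

All three values come from a functional assay on L5178Y cells (Mus musculus) for antiproliferative activity, read by MTT assay (on this read-out higher numbers stand for weaker inhibition and lower numbers for stronger inhibition), and lie within the usual scatter of one another, so compound 2 stands level with the other two. Compound 4 `CC(C)(C)c1ccc(OCCCCN2CCN(c3cccnc3)CC2)cc1` carries tert-butyl in place of acetyl on an aromatic carbon of compound 2: tert-butyl in place of acetyl on an aromatic carbon. Among the measured compounds shown here, the only measured step, a 1.0-fold lower number from compound 2 to compound 3 (0.00 log units; within the scatter), puts pyridin-2-yl in place of pyridin-3-yl on an amine nitrogen in a ring and leaves acetyl untouched, so it offers no direct guide. The starting point is therefore the value of compound 2, 24.2 nM, with no direction foreseen. The expected change is a 1.0-fold lower number from compound 2 to compound 4 (0.00 log units; within the scatter), which is no step beyond the scatter. For compound 4 the estimated value is 24 nM, with an expected range from 8 nM to 75 nM.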

Compound 4, half-maximal inhibitory concentration: 5.48 nM
The estimate for compound 4 lay 4.4-fold (0.64 log units) above the measured number, and the stated range ends above it.
By their numbers in this assay, from the lowest: compound 4; then compounds 3, 2 and 1 (each within the scatter of the next).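

With tert-butyl in place of acetyl on this aromatic carbon, para to a large group, this assay shows a 4.4-fold lower number from compound 2 to compound 4 (0.65 log units; beyond the scatter), so the acetyl group, with its carbonyl, is not needed for activity in this compound. Changing this group moved the number beyond the scatter, whereas the pyridine change, a 1.0-fold lower number from compound 2 to compound 3 (0.00 log units; within the scatter), did not. No available evidence explains this difference.

Going by these compounds, whether other groups on this carbon, such as methyl or a carboxylic acid, would match tert-butyl remains open. So does whether tert-butyl would give a similar step alongside pyridin-2-yl.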